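Nitro in place of hydroxy on compound 2

The compounds below may be only part of what the source reports. "The series", "measured", "known", "first", "only" and "open" are said of these compounds alone.

Within the data shown here, in a functional assay on HeLa cells (Homo sapiens) for antiproliferative activity, read by sulforhodamine B assay, with a stated time of 48 h (a lower number here means a stronger inhibitor, a higher number a weaker inhibitor), compound 1 `COc1cc(OC)c2sc(-c3ccc(N/C=C\C(=O)c4ccc(OC)c([N+](=O)[O-])c4)c(C)c3)nc2c1` gives 9390 nM and compound 2 `COc1cc(OC)c2sc(-c3ccc(N/C=C\C(=O)c4ccc(OC)c(O)c4)cc3)nc2c1` gives 12100 nM, so compound 2 stands within the scatter of the only other measured number. Still unmeasured is compound 3 `COc1cc(OC)c2sc(-c3ccc(N/C=C\C(=O)c4ccc(OC)c([N+](=O)[O-])c4)cc3)nc2c1`, which differs from compound 2 by nitro in place of hydroxy on an aromatic carbon, ortho to a methoxy group: nitro in place of hydroxy on an aromatic carbon. The same difference reads 3-hydroxy-4-methoxyphenyl to 4-methoxy-3-nitrophenyl. Among the measured compounds shown here, no measured pair shows this change alone. The 4-methoxy-3-nitrophenyl group of compound 3 also occurs in compound 1, which carries an additional methyl group and gives 9390 nM, so no step beyond the scatter is expected in this assay. The expected change is a 1.3-fold lower number from compound 2 to compound 3 (0.13 log units; within the scatter). Compound 3 is estimated at 9000 nM, with an expected range of 3000 nM to 27000 nM.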

Compound 3, half-maximal inhibitory concentration: 12900 nM
Compound 3: the middle estimate sits 1.4-fold (0.16 log units) below what was measured, within the range that was stated.
By their numbers in this assay, from the lowest: compounds 1, 2 and 3 (each within the scatter of the next).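

In this assay, nitro in place of hydroxy on an aromatic carbon, ortho to a methoxy group, can now be read alone: it gives a 1.1-fold higher number from compound 2 to compound 3 (0.03 log units; within the scatter), so the change from 3-hydroxy-4-methoxyphenyl to 4-methoxy-3-nitrophenyl shows no step beyond the scatter, even though a hydrogen-bond donor leaves. The second pair isolates a different place, where hydrogen in place of methyl on an aromatic carbon gives a 1.4-fold higher number from compound 1 to compound 3 (0.14 log units; within the scatter), also within the scatter. Nothing measured alongside these numbers speaks to their cause.

The compounds shown leave open whether an amine, a carboxylic acid or a longer alkoxy chain at this position would give a step beyond the scatter. They also leave open whether any change to the shared core would move the number in this assay.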